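This account rests on a few compounds, and the source may have more. Where it says the series, first, only, none or still open, it means among the compounds named here.

Working notes on the chain series, read in a functional assay on HCT-116 cells (Homo sapiens) for antiproliferative activity, read by MTT assay, with a stated time of 48 h; on this read-out lower numbers stand for stronger inhibition and higher numbers for weaker inhibition. Compound 1 `CCCCCCC(CCO)n1cnc2c(OC)ncnc21` reaches a limit of the assay and gives no number (> 50000 nM). Going by the values given here, compound 2 `CCCCCCCCC(CCO)n1cnc2c(OC)ncnc21` gives 12800 nM in this assay, the only true number so far. The other reading stands as a limit (the limit of > 50000 nM in this assay, at which 1 of the 2 values shown sits), so compound 2 cannot yet be ranked against a spread of values.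

Compound 3 `CCCCCCCCCC(CCO)n1cnc2c(OC)ncnc21` carries methyl in place of hydrogen on a saturated chain carbon, nine bonds along the chain from an aromatic nitrogen. Among the compounds with values here, one measured step bears on this change: ethyl in place of hydrogen on a saturated chain carbon, seven bonds along the chain from an aromatic nitrogen, which gives an at least 3.9-fold lower number from compound 1 to compound 2 (0.59 log units; beyond the scatter) and lies beyond the scatter. A single step sets no trend, and the new group is smaller than ethyl. A modest move to a lower number in this assay is therefore expected, in the same direction as the step of an at least 3.9-fold lower number from compound 1 to compound 2 (0.59 log units; beyond the scatter) but possibly not clear of the scatter. The expected change is a 1.8-fold lower number from compound 2 to compound 3 (0.26 log units; within the scatter) as an estimate. For compound 3 the estimated value is 7000 nM (expected range 2500 nM to 20000 nM).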

Compound 3, half-maximal inhibitory concentration: 2530 nM
Estimate against measurement, compound 3: 2.8-fold (0.44 log units) above; low and high end bracket the measured number.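

In this assay, methyl in place of hydrogen on a saturated chain carbon, nine bonds along the chain from an aromatic nitrogen, gives a 5.1-fold lower number from compound 2 to compound 3 (0.70 log units; beyond the scatter). Going by these compounds alone, this is the first step read between two true numbers, and it shows that adding 1 carbon at the chain end still moves the read-out beyond the scatter, in the same direction as the ethyl step before it. Over the whole stretch, propyl in place of hydrogen at the position seven bonds along the chain from an aromatic nitrogen gives an at least 19-fold lower number from compound 1 to compound 3 (1.29 log units; beyond the scatter), but compound 1 stands at a limit and not at a number, so this step is only a bound: the limit of > 50000 nM in this assay, at which 1 of the 3 values shown sits.

The three compounds shown leave open whether a longer chain than that of compound 3 keeps lowering the number, levels off or reverses the run. They also leave open how far this chain effect holds when the hydroxyl of the chain gives way to an amine or a carboxylic acid.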